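Second methoxy added back to the compound 3 chalcone

A few compounds are considered here, and "the series" means these few. Any claim that something is new, unique, unknown or untested is made for them only; others in the source may bear on it.

For the measured compounds named here, compound 3 `COc1ccccc1/C=C/C(=O)c1ccc[nH]1` sits lowest of the three numbers so far: in an assay for inhibition of cytochrome P450 1A1 (Homo sapiens), read by fluorescence, using microsomes, with a stated time of 10 min (on this read-out lower numbers stand for stronger inhibition and higher numbers for weaker inhibition), compound 3 gives 900 nM, while compound 2 `COc1cccc(/C=C/C(=O)c2ccc[nH]2)c1OC` gives 5200 nM and compound 1 `COc1ccc(/C=C/C(=O)c2ccc[nH]2)c(OC)c1` gives 11800 nM. Both measured steps reach compound 3 by the same kind of change, hydrogen in place of methoxy on an aromatic carbon: a 13-fold lower number from compound 1 to compound 3 (1.12 log units; beyond the scatter) and a 5.8-fold lower number from compound 2 to compound 3 (0.76 log units; beyond the scatter).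

Compound 4 `COc1cccc(OC)c1/C=C/C(=O)c1ccc[nH]1` goes the other way. The change methoxy in place of hydrogen on an aromatic carbon is the mirror of those two steps, so in this assay a rise of the number is expected, of a size between the two removals already seen, though its methoxy does not stand where either of the removed groups stood, so the match is loose. The expected step is a 5.6-fold higher number from compound 3 to compound 4 (0.74 log units; beyond the scatter). Compound 4 is therefore estimated at 5000 nM, within 1500 nM to 16000 nM.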

Compound 4, half-maximal inhibitory concentration: 10800 nM
The estimate for compound 4 lay 2.2-fold (0.33 log units) below the measured number; the measured number falls inside the stated range.
By their numbers in this assay, from the lowest: compound 3; then compound 2; then compounds 4 and 1 (each within the scatter of the next).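

For the compounds shown here, the step of a 12-fold higher number from compound 3 to compound 4 (1.08 log units; beyond the scatter) is the first addition read directly at this place, on an aromatic carbon ortho to a group of 9 heavy atoms and meta to a methoxy group, and it is large in this assay. Compound 1, compound 2 and compound 4 each carry a second methoxy at a different place and all stand at higher numbers than compound 3, with no compound shown going against this. Nothing on hand gives a reason for the rise.

The compounds shown leave open whether a hydroxyl, a fluorine or an ethoxy at this place would raise the number as methoxy does. They also leave open whether an amine here would give a number lower than that of compound 3 with its hydrogen.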